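Methoxy for Ethyl on a Weakly Cytotoxic Pair

The source may hold more compounds than are shown below. What is called first, only, known or untested is meant among the compounds shown, and "the series" means these compounds.

Of the compounds shown here, two sharing one core have been tested in a functional assay on HepG2 cells (Homo sapiens) for cytotoxicity, read by MTT assay, with a stated time of 72 h; a lower number here means a stronger inhibitor, a higher number a weaker inhibitor. Compound 1 `COc1ccc(-c2ccnc(C(=O)Nc3ccc(Oc4ccnc5[nH]ccc45)cc3)c2)cc1` gives 11700 nM in this assay. Compound 2 `CCc1ccc(-c2ccnc(C(=O)Nc3ccc(Oc4ccnc5[nH]ccc45)c(F)c3)c2)cc1` differs from it in two places, and in this assay compound 2 gives 10400 nM. That is the lower of the two numbers, but the gap to compound 1 lies within the scatter, so the two cannot be ordered.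

Compound 3 `COc1ccc(-c2ccnc(C(=O)Nc3ccc(Oc4ccnc5[nH]ccc45)c(F)c3)c2)cc1` has not been measured. The change from compound 2 to compound 3 is methoxy in place of ethyl on an aromatic carbon, so compound 3 carries the methoxy of compound 1 together with the fluorine of compound 2. Within the data shown here, no step between measured compounds is available. Because compound 1 with 11700 nM and compound 2 with 10400 nM sit within the scatter of each other, no step beyond the scatter is expected in either direction. The expected step from compound 2 to compound 3 is a 1.1-fold higher number from compound 2 to compound 3 (0.02 log units; within the scatter). Compound 3 is estimated at 11000 nM, within a range from 5000 nM to 25000 nM.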

Compound 3, half-maximal inhibitory concentration: 13300 nM
Beside the measured number, compound 3's estimate is 1.2-fold (0.08 log units) below it, within the range that was stated.
By their numbers in this assay, from the lowest: compounds 2, 1 and 3 (each within the scatter of the next).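

With compound 3 measured, two single-place comparisons can be read in this assay, one for each place in which compound 1 and compound 2 differ. Methoxy in place of ethyl, on an aromatic carbon para to a large group, gives a 1.3-fold higher number from compound 2 to compound 3 (0.11 log units; within the scatter), and fluoro in place of hydrogen on an aromatic carbon gives a 1.1-fold higher number from compound 1 to compound 3 (0.06 log units; within the scatter), so neither change, taken alone, separates its pair beyond the scatter. Nothing on hand bears on why these compounds read alike.

The compounds shown cover only the 4-ethylphenyl and 4-methoxyphenyl groups, so it remains open whether an amine, a carboxylic acid or a longer alkyl chain at this position would give a step beyond the scatter. From the compounds shown here alone, whether fluoro would read the same with any of those groups in place also remains open.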